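Methoxyphenyl Sulfonamide Tested Against a Series at the Limit

The source may report more compounds than this note shows. Statements on the series, on what has been measured and on what is new or still open speak of the compounds shown alone.

Three sulfonamides have been measured in an assay on isolated protein for inhibition of malate dehydrogenase, mitochondrial (Sus scrofa), with stated times of 45 min and 30 min; on this read-out higher numbers stand for weaker inhibition and lower numbers for stronger inhibition. Compound 1 `Cc1ccc(S(=O)(=O)Nc2ccc3oc(-c4ccccc4)nc3c2)cc1` carries 4-methylphenyl on the sulfonyl sulfur, and in this assay compound 1 gives > 63000 nM, a limit of the assay rather than a number. Compound 2 `COc1cccc(S(=O)(=O)Nc2ccc3oc(-c4ccccc4)nc3c2)c1` carries 3-methoxyphenyl in place of 4-methylphenyl on the sulfonyl sulfur, and in this assay compound 2 gives > 63000 nM, again only a limit. The step that the two limits leave unreadable from compound 1 to compound 2 therefore cannot be read. Compound 3 `O=S(=O)(Nc1ccc(-c2nc3ccccc3o2)cc1)c1cccs1`, built on a differently arranged core, bears thiophen-2-yl on the sulfonyl sulfur, and in this assay compound 3 gives > 63000 nM, a limit as well. Compound 3 thus stands where every measured value stands, at the limit of > 63000 nM in this assay, at which 3 of the 3 values shown sit, and no ordering among the three can be drawn.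

Compound 4 `COc1cccc(S(=O)(=O)Nc2ccc(-c3nc4ccccc4o3)cc2)c1` differs from compound 3 by 3-methoxyphenyl in place of thiophen-2-yl on a sulfonyl sulfur. Among the compounds with values here, no measured step reads on this change: the only single-point step, from compound 1 to compound 2, is unreadable, and compound 2, which already carries 3-methoxyphenyl on a sulfonyl sulfur, sits at the same limit. The expectation in this assay is therefore no step beyond the scatter, with compound 4 most likely also returning a limit. The estimate for compound 4 in this assay is 80000 nM, between 30000 nM and 300000 nM. The implied step that the limit leaves unreadable from compound 3 to compound 4 is expected to stay within the scatter.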

Compound 4, half-maximal inhibitory concentration: > 63000 nM
Compound 4: only a limit was reported; the forecaster's own chance of this, stated with the estimate: 85%; the middle value is on the limit's open side.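

Compound 4, like compound 3, returns only a limit in this assay, so no step between compound 3 and compound 4 can be read, and the series stays where it was: the limit of > 63000 nM in this assay, at which 4 of the 4 values shown sit.

The compounds shown leave open how strongly any of them inhibits, and whether any group on the sulfonyl sulfur would give a value that is more than a limit.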